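Methoxy for cyclopropyl on the shared core

This account rests on a few compounds, and the source may have more. Where it says the series, first, only, none or still open, it means among the compounds named here.

In an ADME assay on microsomes from liver (Rattus norvegicus) for metabolic stability, read by LC-MS, using NADPH, with stated times of 10 min and 60 min (on this read-out lower numbers stand for slow clearance and higher numbers for fast clearance), compound 1 (`CCc1nc(CN(C)C2CCCc3cccnc32)cc(N2CCN(C)CC2)n1`) gives 2090 mL/min/kg and compound 2 (`CN1CCN(c2cc(CN(C)C3CCCc4cccnc43)nc(C3CC3)n2)CC1`) gives 2440 mL/min/kg. These two numbers lie within the scatter of each other, so compound 2 stands level with compound 1.

The next step leads to compound 3 (`COc1nc(CN(C)C2CCCc3cccnc32)cc(N2CCN(C)CC2)n1`), which has not yet been measured: methoxy in place of cyclopropyl on an aromatic carbon. In words, this is methoxy in place of cyclopropyl on an aromatic carbon, between two ring nitrogen atoms and meta to a 4-methylpiperazin-1-yl group.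

Among the measured compounds shown here, one measured step bears on this change: a 1.2-fold higher number from compound 1 to compound 2 (0.07 log units; within the scatter), which was cyclopropyl in place of ethyl on an aromatic carbon. That step stayed within the scatter. For the measured compounds named here, it is limited guidance, as no measured compound carries methoxy. On this evidence, no step beyond the scatter is expected in this assay, and no direction is favoured.

The estimated step is a 1.1-fold lower number from compound 2 to compound 3 (0.04 log units; within the scatter). Compound 3 is expected at 2200 mL/min/kg, with an estimated range of 1200 mL/min/kg to 3600 mL/min/kg.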

Compound 3, clearance: 1130 mL/min/kg
Compound 3: the middle estimate sits 1.9-fold (0.29 log units) above what was measured; measured number below the stated range.
By their numbers in this assay, from the lowest: compounds 3, 1 and 2 (each within the scatter of the next, the first and the last beyond it).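

Among the compounds shown here, at this position, on an aromatic carbon between two ring nitrogen atoms, methoxy gives the first step beyond the scatter in this assay (a 2.2-fold lower number from compound 2 to compound 3 (0.33 log units; beyond the scatter)), and that step is modest. Measured against ethyl, the same group stays within the scatter (a 1.8-fold lower number from compound 1 to compound 3 (0.27 log units; within the scatter)), so the series separates methoxy clearly from cyclopropyl only, while ethyl cannot be told apart from either, and a change at this position can therefore move the clearance reading, though only slightly beyond the usual spread. No supporting measurement accounts for the step from compound 2 to compound 3.

With a single oxygen-linked group in hand, these compounds cannot show whether the lower number belongs to methoxy alone or extends to a longer chain such as ethoxy, or to an amine such as dimethylamino at the same position. All three compounds also keep the 4-methylpiperazin-1-yl group unchanged, so they leave open whether the methoxy step holds when that group is replaced, for example by morpholine.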